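Compound 4 Against a Row of Limits

The source may report more compounds than this note shows. Statements on the series, on what has been measured and on what is new or still open speak of the compounds shown alone.

In an ADME assay on MCF7 cells (Homo sapiens) for cytotoxicity, with a stated time of 72 h (on this read-out higher numbers stand for weaker inhibition and lower numbers for stronger inhibition), three compounds have been measured and none yields an exact number. Compound 1 `COc1ccc(CNc2ncnc3c2ncn3C2CCCCO2)cc1` gives > 100000 nM, which is a limit. Compound 2 `Oc1ccccc1CNc1ncnc2c1ncn2C1CCCO1` gives > 100000 nM, again a limit. Compound 3 `COc1cccc(CNc2ncnc3c2ncn3C2CCCO2)c1` gives > 100000 nM, also a limit, and it stands with the others at the limit of > 100000 nM in this assay, at which 3 of the 3 values shown sit. Compound 4 `COc1ccc(CNc2ncnc3c2ncn3C2CCCO2)cc1` places 4-methoxyphenyl in place of 3-methoxyphenyl, on a saturated chain carbon bound to a nitrogen on an aromatic ring (4-methoxyphenyl in place of 3-methoxyphenyl on a saturated chain carbon bound to a nitrogen on an aromatic ring). Within the data shown here, the one measured step that bears on this change is a step that the two limits leave unreadable from compound 2 to compound 3, so it offers no size to carry over. In this assay the expected change, a number no higher from compound 3 to compound 4 (the limit leaves the size open), is none beyond the scatter, in neither direction. The estimate for compound 4 is 100000 nM, with an expected range of 40000 nM to 200000 nM.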

Compound 4, half-maximal inhibitory concentration: > 100000 nM
Compound 4: a limit, no number (the forecaster's own chance of this, stated with the estimate: 85%); the middle value lies on the limit itself.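

Among these compounds, no step from compound 1, compound 2 or compound 3 to compound 4 can be read, since all four compounds stand at a limit: the limit of > 100000 nM in this assay, at which 4 of the 4 values shown sit. In this assay the compounds shown leave open whether any of these changes shifts the read-out at all.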